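A few compounds are considered here, and "the series" means these few. Any claim that something is new, unique, unknown or untested is made for them only; others in the source may bear on it.

Series notes. In an in vitro ADME assay on microsomes from liver (Mus musculus) for pharmacokinetics, read by LC-MS, with a stated time of 10 min, tested at 1 uM (a higher number here means faster removal of the compound, a lower number slower removal), compound 1 `CN1C[C@H](C(=O)Nc2ccccc2)[C@@H](c2ccc(/C=C/C(=O)Nc3ccccc3N)cc2)C1` gives 67 mL/min/kg, compound 2 `CC(C)c1ccc(NC(=O)[C@H]2CN(C)C[C@@H]2c2ccc(/C=C/C(=O)Nc3ccccc3N)cc2)cc1` gives 54 mL/min/kg and compound 3 `CN1C[C@H](C(=O)Nc2cccc(Cl)c2)[C@@H](c2ccc(/C=C/C(=O)Nc3ccccc3N)cc2)C1` gives 58 mL/min/kg. Compound 3 thus holds the second highest of the three numbers, though all three lie within the scatter of one another: a 1.2-fold lower number from compound 1 to compound 3 (0.06 log units; within the scatter), a 1.1-fold higher number from compound 2 to compound 3 (0.03 log units; within the scatter) and a 1.2-fold lower number from compound 1 to compound 2 (0.09 log units; within the scatter). Compound 4 `Cc1cc(NC(=O)[C@H]2CN(C)C[C@@H]2c2ccc(/C=C/C(=O)Nc3ccccc3N)cc2)ccc1F` is not yet measured; it differs from compound 3 by 4-fluoro-3-methylphenyl in place of 3-chlorophenyl on an amide-type nitrogen. Bearing on this are the two measured exchanges on the same aryl amide, chloro for hydrogen and 3-chlorophenyl for 4-isopropylphenyl, neither of which gave a step in this assay beyond the scatter. No step beyond the scatter is therefore expected for compound 4: no change at the digits printed from compound 3 to compound 4 (within the scatter). Compound 4 is estimated at 58 mL/min/kg, with a range of 35 mL/min/kg to 95 mL/min/kg.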

Compound 4, clearance: 62 mL/min/kg
The estimate for compound 4 lay 1.1-fold (0.03 log units) below the measured number, and the stated range covers the measured number.
By their numbers in this assay, from the lowest: compounds 2, 3, 4 and 1 (each within the scatter of the next).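

In this assay, 4-fluoro-3-methylphenyl on the amide-type nitrogen stays within the scatter of all three earlier aryl groups: (a 1.1-fold higher number from compound 3 to compound 4 (0.03 log units; within the scatter)), (a 1.1-fold higher number from compound 2 to compound 4 (0.06 log units; within the scatter)) and (a 1.1-fold lower number from compound 1 to compound 4 (0.03 log units; within the scatter)). Fluoro and methyl together on this ring thus extend the flat picture beyond single chloro or isopropyl substitution, and the four aryl amides remain unseparated at this position. Nothing available explains this flatness.

Still open, from the compounds shown here alone, is whether an amine or a carboxylic acid on this ring would move the number. Also open, going by these compounds, is whether a longer chain in place of the ring would do so.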